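The source may report more compounds than this note shows. Statements on the series, on what has been measured and on what is new or still open speak of the compounds shown alone.

Compound 1 `COc1ccc2occ(CSC(=S)N3CCOCC3)c(=O)c2c1`: 4800 nM
Compound 2 `COc1ccc2occ(CSC(=S)N3CCCC3)c(=O)c2c1`: 3100 nM
Compound 3 `O=c1c(Cl)c(CSC(=S)N2CCCC2)oc2ccccc12`: 600 nM

The three measured compounds were tested in a functional assay on HEp-2 cells (Homo sapiens) for antiproliferative activity, read by MTT assay, with a stated time of 72 h; a higher number here means a weaker inhibitor, a lower number a stronger inhibitor. Compound 3 has the lowest number of the three; the nearest to it is compound 2, and the difference between the cores of compound 3 and compound 2 is not broken down here. Compound 1 and compound 2 share a core and differ in a single place, namely (morpholin-4-yl in place of pyrrolidin-1-yl on a thiocarbonyl carbon). That change gave a 1.5-fold higher number from compound 2 to compound 1 (0.19 log units; within the scatter), a step that stays within the usual scatter of this assay.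

Compound 4 `O=c1c(Cl)c(CSC(=S)N2CCOCC2)oc2ccccc12` has not yet been measured in this assay. Among the compounds with values here, it differs from compound 3 by morpholin-4-yl in place of pyrrolidin-1-yl on a thiocarbonyl carbon, which is the same change as the one from compound 2 to compound 1, here made on the core of compound 3. The expectation for compound 4 rests on that one earlier step: because a 1.5-fold higher number from compound 2 to compound 1 (0.19 log units; within the scatter) was small, the corresponding step on the core of compound 3 is expected to be small too, with the number for compound 4 expected to sit close to that of compound 3. Compound 4 is therefore estimated at 900 nM, between 450 nM and 1900 nM, which corresponds to an expected step of a 1.5-fold higher number from compound 3 to compound 4 (0.18 log units; within the scatter).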

Compound 4, half-maximal inhibitory concentration: 9000 nM
For compound 4 the middle estimate is 10-fold (1.00 log units) below the measured one, outside the stated range (above it).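

In this assay, putting morpholin-4-yl in place of pyrrolidin-1-yl on the thiocarbonyl carbon of compound 3 gave a 15-fold higher number from compound 3 to compound 4 (1.18 log units; beyond the scatter), and the size of this change therefore did not carry over from one core to the other: the same change on two cores in this assay, a 1.5-fold higher number (0.19 log units; within the scatter) from compound 2 to compound 1 and a 15-fold higher number (1.18 log units; beyond the scatter) from compound 3 to compound 4, 9.7-fold (0.99 log units) apart, beyond the scatter of two such steps

The step is beyond the scatter only on the core of compound 3, so in this series the result on one core is no safe guide to the result on the other. With a single pair on each of two cores, this does not show which feature of the cores sets the size of the step, nor how a third core would respond.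

The compounds shown leave open whether another amine on the thiocarbonyl carbon, such as piperidin-1-yl or dimethylamino, would behave more like pyrrolidin-1-yl or morpholin-4-yl on either core. They also leave open how the same change would fare on a core that carries only some of the differences between these two cores.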